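The compounds below may be only part of what the source reports. "The series", "measured", "known", "first", "only" and "open" are said of these compounds alone.

Measured in an ADME assay on cells (Macrophage) for cytotoxicity, read by resazurin assay, with a stated time of 48 h; a higher number here means that more compound is tolerated, a lower number that less compound is tolerated:
- Compound 1 `Nc1nc(-c2ccc(Cl)cc2)cc(-c2ccc(OCc3cn(Cc4ccccc4)nn3)cc2O)n1`: 66600 nM
- Compound 2 `CCCCCCn1cc(COc2ccc(-c3cc(-c4ccccc4)nc(N)n3)c(O)c2)nn1`: "not determined" (no result reported)

Compound 2 offers no number as a starting point, since its entry in this assay reads "not determined" (no result reported). The next structure is compound 3 `Nc1nc(-c2ccccc2)cc(-c2ccc(OCc3cn(Cc4ccccc4)nn3)cc2O)n1`, which has not yet been measured. The change is phenyl in place of pentyl on a saturated chain carbon bound to an aromatic nitrogen, which also reads as hexyl to benzyl. Without a value at its starting point, this step cannot be sized directly. For the measured compounds named here, the only guide is compound 1, which also carries the benzyl and gives 66600 nM. Compound 3 is therefore expected to lie close to that value, with no difference beyond the usual scatter. For compound 3 the estimated value is 70000 nM, with an expected range of 30000 nM to 150000 nM.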

Compound 3, half-maximal cytotoxic concentration: 76500 nM
Beside the measured number, compound 3's estimate is 1.1-fold (0.04 log units) below it, and the stated range covers the measured number.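

Hydrogen in place of chloro on an aromatic carbon gives a 1.1-fold higher number from compound 1 to compound 3 (0.06 log units; within the scatter), so in this assay this swap shows no measurable effect, and the chloro group is not needed for the level of tolerance seen with compound 1. The change from hexyl to benzyl cannot be read, since compound 2 has no number to compare with. No measured property accompanies these values that could explain them.

Going by these compounds, whether a larger or different group at the chloro position, such as a methoxy or an amine, would also leave this assay unchanged stays open. How a hexyl chain compares with benzyl, or how a longer chain or a carboxylic acid would behave on the saturated chain carbon bound to an aromatic nitrogen, is also unresolved.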